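Compound 4 and a Limit Shared by Its Neighbours

A few compounds are considered here, and "the series" means these few. Any claim that something is new, unique, unknown or untested is made for them only; others in the source may bear on it.

Compound 1 (`CSC1=NC(c2cccc([N+](=O)[O-])c2)C2=C(O)OCC2=N1`) is the starting point in a functional assay (aorta) with Oryctolagus cuniculus as the target; a higher number here means that more compound is needed for the effect, a lower number that less compound is needed. Compound 1 reads > 30000 nM as a limit of the assay and not a number. Compound 2 (`CSC1=NC(c2ccccc2SC)C2=C(O)OCC2=N1`) reads > 30000 nM; > 30000 nM; > 30000 nM (3 entries) as a limit too. Compound 3 (`CSC1=NC(c2cccc([N+](=O)[O-])c2SC)C2=C(O)OCC2=N1`) reads > 30000 nM as a limit too. The evidence so far is the limit of > 30000 nM in this assay, at which 2 of the 3 values shown sit, and nothing firmer. Compound 4 (`CSC1=NC(c2cc([N+](=O)[O-])ccc2SC)C2=C(O)OCC2=N1`) carries one change from compound 1 (methylsulfanyl in place of hydrogen on an aromatic carbon), methylsulfanyl in place of hydrogen on an aromatic carbon. The closest measured change is a step that the two limits leave unreadable from compound 1 to compound 3 and it makes the same exchange in another place. With no readable size there, no definite step in either direction is expected in this assay for this change. The estimated step is a number no higher from compound 1 to compound 4 (the limit leaves the size open) and remains a rough expectation. Compound 4 is expected near 30000 nM with an estimated range from 12000 nM to 60000 nM and will probably be reported as a limit again.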

Compound 4, half-maximal effective concentration: > 30000 nM
Compound 4: a limit, no number; the forecaster's own chance of this, stated with the estimate: 85%; the middle value lies on the limit itself.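

Compound 1 and compound 4 both read as limits of the assay and not as numbers, so no step can be read between them. Still open is what concentration any of the four compounds needs for the effect, and whether the place of the methylsulfanyl group matters; the evidence stays at one point: the limit of > 30000 nM in this assay, at which 3 of the 4 values shown sit.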